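The source may report more compounds than this note shows. Statements on the series, on what has been measured and on what is new or still open speak of the compounds shown alone.

In a functional assay (Hippocampus) with Rattus norvegicus as the target (on this read-out lower numbers stand for lower potency and higher numbers for higher potency (the scale is a negative logarithm)), compound 1 `COC(=O)C1CC2CC1N(C)C2` gives 5.4 and compound 2 `COC(=O)C1CC2CNC1C2` gives 5.5, so these two compounds sit within the scatter of each other. Within the data shown here, the only measured step is a number 0.10 log units higher from compound 1 to compound 2 (within the scatter), with hydrogen in place of methyl on an amine nitrogen in a ring.

The next compound, compound 3 `COC(=O)[C@H]1C[C@@H]2CN[C@H]1C2`, has no new group. The change is the two compounds have the same atoms and bonds; at least one stereo element is drawn with a configuration in one of them and without one in the other: 3 of 3 stereo elements differ; a stereocentre at a saturated ring carbon is drawn without a configuration in compound 2 and S in compound 3; a stereocentre at a saturated ring carbon is drawn without a configuration in compound 2 and S in compound 3; a stereocentre at a saturated ring carbon is drawn without a configuration in compound 2 and S in compound 3. Compound 3 therefore has a fully drawn configuration, whereas the drawing of compound 2 leaves its configuration open, and it does not show what stereochemical form was tested.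

Among the measured compounds shown here, the measured step bears on this only weakly, since it concerns a group on nitrogen and no measured pair here isolates a change in configuration. The data therefore give neither a firm size nor a firm direction, and a shift either way is possible. With compound 2 at 5.5 as the anchor, the best guess is no change beyond the scatter in this assay.

The expected change is a number 0.10 log units higher from compound 2 to compound 3 (within the scatter). For compound 3, the estimated value is 5.6, with an expected range from 4.9 to 6.2.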

Compound 3, negative logarithm of the half-maximal effective concentration: < 4
Compound 3 ended at the assay's limit; the forecaster's own chance of this, stated with the estimate: 5%; at least 1.60 log units between middle value and limit.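

With no atom or bond changed, the S configuration drawn at all three stereocentres of compound 3 goes with a number at least 1.50 log units lower from compound 2 to compound 3 (beyond the scatter) in this assay. Compound 3 gives < 4, which is a limit of this assay and not a number. The earlier step concerned only a group on nitrogen and stayed within the scatter, whereas this result shows that the same atoms and bonds can give very different read-outs once a configuration is specified, although the comparison is not between two fully defined forms: the fact that one of compounds 2 and 3 is drawn with a defined configuration and the other without, at the place where they differ

The compounds shown leave open which stereochemical form of compound 2 gave its value, whether that was a single form or a mixture, and which of the three stereocentres matters most for the difference. They also leave open whether the opposite configuration at all three stereocentres would restore the read-out, and whether a carboxylic acid or an amide in place of the methyl ester would show the same dependence on configuration.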